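The compounds below may be only part of what the source reports. "The series", "measured", "known", "first", "only" and "open" are said of these compounds alone.

Measured so far:
Compound 1 `COc1ccccc1-n1nncc1CN1C(=O)C2(C(C#N)=C(N)Oc3c2c2nc4ccccc4nc2c2ccccc32)c2ccccc21` gives in an ADME assay on HUVEC cells (Homo sapiens) for antiproliferative activity, read by MTT assay, with a stated time of 48 h (a lower number here means a stronger inhibitor, a higher number a weaker inhibitor), only a limit of the assay, > 50000 nM.
Compound 2 `CCOc1ccccc1-n1nncc1CN1C(=O)C2(C(C#N)=C(N)Oc3c2c2nc4ccccc4nc2c2ccccc32)c2ccccc21` gives in this assay only a limit, > 50000 nM.
Compound 3 `Cc1ccc(-n2nncc2CN2C(=O)C3(C(C#N)=C(N)Oc4c3c3nc5ccccc5nc3c3ccccc43)c3ccccc32)cc1C` gives in this assay only a limit, > 50000 nM.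

Compound 1 therefore stands at the edge of what this assay can report, with no number of its own; the same is true of every compound measured, since (the limit of > 50000 nM in this assay, at which 3 of the 3 values shown sit). The compound to be measured next is compound 4 `N#CC1=C(N)Oc2c(c3nc4ccccc4nc3c3ccccc23)C12C(=O)N(Cc1cnnn1-c1ccc(Cl)c(Cl)c1)c1ccccc12`, which differs from compound 1 in one place: 3,4-dichlorophenyl in place of 2-methoxyphenyl on an aromatic nitrogen.

The measured steps that bear on this change are those that also swap the aryl group on the aromatic nitrogen, a step that the two limits leave unreadable from compound 1 to compound 3 and a step that the two limits leave unreadable from compound 2 to compound 3, and the smaller change a step that the two limits leave unreadable from compound 1 to compound 2. None of them can be sized, as both ends of each sit at the limit. So there is no ground to expect any readable step in this assay, in either direction. Compound 4 is expected to give about 80000 nM, in a range from 30000 nM to 300000 nM, most likely again reported only as a limit. The step expected from compound 1 is a step that the limit leaves unreadable from compound 1 to compound 4, which is an estimate rather than a measurement.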

Compound 4, half-maximal inhibitory concentration: > 50000 nM
Compound 4 was reported as a limit; the forecaster's own chance of this, stated with the estimate: 85%; the middle value is on the limit's open side.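

In this assay compound 4 gives only the limit > 50000 nM and no number of its own. Its steps from compound 1, compound 2 and compound 3 therefore cannot be read. Whether any aryl group on the aromatic nitrogen changes activity stays open, since all four compounds share one ceiling: the limit of > 50000 nM in this assay, at which 4 of the 4 values shown sit.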